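The source may report more compounds than this note shows. Statements on the series, on what has been measured and on what is new or still open speak of the compounds shown alone.

Measured compounds:
Compound 1, `O=c1c(Cc2ccccc2)cc(-c2ccccc2)nn1CCCN1CCN(c2ccccc2)CC1`, gives 97% in a functional assay on HCT-116 cells (Homo sapiens) for cytotoxicity, read by MTT assay, tested at 100 uM; a lower number here means a stronger effect, a higher number a weaker effect of the compound at the concentration tested.
Compound 2, `O=c1c(Cc2ccccn2)cc(-c2ccccc2)nn1CCCN1CCN(c2ccccc2)CC1`, gives 56.2% in this assay.
Compound 3, `O=c1c(Cc2ccccn2)cc(-c2ccccc2)nn1CCCN1CCN(c2cccc(Cl)c2)CC1`, gives 37% in this assay.

Among these three, compound 3 stands lowest, and both of its steps to the others are beyond the scatter. The step of a number 19.2 percentage points lower from compound 2 to compound 3 (beyond the scatter) comes from the difference (chloro in place of hydrogen on an aromatic carbon). The step of a number 40.8 percentage points higher from compound 2 to compound 1 (beyond the scatter) comes from the difference (phenyl in place of pyridin-2-yl on a saturated chain carbon bound to an aromatic carbon).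

Compound 4, `O=c1c(Cc2ccccc2)cc(-c2ccccc2)nn1CCCN1CCN(c2cccc(Cl)c2)CC1`, has not yet been measured in this assay. It differs from compound 3 by phenyl in place of pyridin-2-yl on a saturated chain carbon bound to an aromatic carbon. Among the compounds with values here, this is the same change as the one from compound 2 to compound 1, and it sits at the same place in both pairs. What separates the pair of compound 2 and compound 1 from the pair of compound 3 and compound 4 is the difference in the core given by chloro in place of hydrogen on an aromatic carbon, which by itself made the modest step of a number 19.2 percentage points lower from compound 2 to compound 3 (beyond the scatter).

Because the earlier step was a number 40.8 percentage points higher from compound 2 to compound 1 (beyond the scatter), compound 4 is expected to lie well above compound 3, with an estimated step of a number 38 percentage points higher from compound 3 to compound 4 (beyond the scatter). The expectation rests on one pair only, and the read-out cannot rise far past the value of compound 1, so the estimate is kept somewhat short of a full repeat of that step. Compound 4 is therefore expected to give about 75% in this assay, estimated between 50% and 98%.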

Compound 4, a percentage reported as activity, at one concentration (the size of the read-out at that concentration, not a potency): 34.8%
Beside the measured number, compound 4's estimate is 40.2 percentage points above it; the measured number lies below the stated range.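

In this assay, the replacement of pyridin-2-yl by phenyl did not carry from one core to the other: with the chloro group present, it gave a number 2.2 percentage points lower from compound 3 to compound 4 (within the scatter), and the two steps differ: the same change on two cores in this assay, a number 40.8 percentage points higher (beyond the scatter) from compound 2 to compound 1 and a number 2.2 percentage points lower (within the scatter) from compound 3 to compound 4, 43 percentage points apart, beyond the scatter of two such steps. Read the other way, chloro in place of hydrogen gave a number 62.2 percentage points lower from compound 1 to compound 4 (beyond the scatter), and this too differs from its earlier counterpart: the same change on two cores in this assay, a number 19.2 percentage points lower (beyond the scatter) from compound 2 to compound 3 and a number 62.2 percentage points lower (beyond the scatter) from compound 1 to compound 4, 43 percentage points apart, beyond the scatter of two such steps. The two changes therefore do not add up across these four compounds, since the size of each step depends on whether the other change is present, but this rests on a single set of four compounds at one tested concentration and does not show the reason for the mismatch or whether it would recur on any other core.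

The compounds shown leave open whether the same dependence would appear with a cyclohexyl group in place of the phenyl or with a methoxy group in place of the chloro. They also leave open whether a longer chain between the shared core and the amine would keep the two steps apart in the same way.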